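A few compounds are considered here, and "the series" means these few. Any claim that something is new, unique, unknown or untested is made for them only; others in the source may bear on it.

Working notes on the series. Compound 1, `NC(=O)[C@@H]1CC[C@H](c2ccc(OCc3ccc(F)cc3)cc2)N1`, is the reference point here. In an ADME assay on the whole organism (Rattus norvegicus) for pharmacokinetics, at a dose of 3 mg/kg by the oral route (on this read-out higher numbers stand for higher oral bioavailability and lower numbers for lower oral bioavailability), compound 1 gives 31%. For the measured compounds named here, the only other measured compound, `NC(=O)[C@@H]1CC[C@H](c2ccc(Oc3ccccc3)cc2)N1`, compound 2, gives in this assay a value of 25%; the two numbers sit within the usual scatter of each other, so compound 1 holds the larger of the two figures without the pair showing any real separation. Going by the values given here, no step between measured compounds is available that mirrors the change to the unmeasured compound `N#Cc1ccccc1COc1ccc([C@H]2CC[C@@H](C(N)=O)N2)cc1`, compound 3, which differs from compound 1 as follows: 2-cyanophenyl in place of 4-fluorophenyl on a saturated chain carbon bound to an oxygen on an aromatic ring. Among the compounds with values here, with no comparable step among the measured pair, only a small step is expected, if any, and none beyond the scatter; the expected step is a number 5 percentage points lower from compound 1 to compound 3 (within the scatter). For compound 3 in this assay the estimate is 26%, ranging from 12% to 40%.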

Compound 3, oral bioavailability: 39%
Estimate against measurement, compound 3: 13 percentage points below; the range from low to high includes it.
By their numbers in this assay, from the lowest: compounds 2, 1 and 3 (each within the scatter of the next, the first and the last beyond it).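

On the saturated chain carbon bound to an oxygen on an aromatic ring, 2-cyanophenyl in place of 4-fluorophenyl gives a number 8 percentage points higher from compound 1 to compound 3 (within the scatter) in this assay and so opens no real separation on this read-out. The position therefore accepts an aromatic ring carrying a nitrile, with its one hydrogen-bond acceptor, without a loss beyond the scatter. No measurement at hand accounts for the figure of compound 3.

On these data alone, whether an amine or a carboxylic acid on the aromatic ring at this place would leave this assay equally undisturbed remains open. For the compounds shown here, also open is whether a longer chain in place of the saturated chain carbon would do the same, since the single step here covers only one exchange of aromatic groups.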